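A few compounds are considered here, and "the series" means these few. Any claim that something is new, unique, unknown or untested is made for them only; others in the source may bear on it.

Measured so far:
compound 1, `CC(C)=CCn1c(CN2CCN(C(=O)C3CC3)CC2)nc2ccccc21`, gives 74.3% in an assay on isolated protein for inhibition of aldehyde dehydrogenase 1A1 (Homo sapiens), read by spectrophotometry, tested at 10 uM; on this read-out higher numbers stand for more inhibition at the one concentration tested (going by the name of the read-out) and lower numbers for less inhibition.
compound 2, `O=C(C1CC1)N1CCN(Cc2nc3ccccc3n2Cc2ccc(F)cc2)CC1`, gives 32.7% in this assay.

Compound 2 stands lowest of the two numbers; its nearest neighbour is compound 1, and the step of a number 41.6 percentage points lower from compound 1 to compound 2 (beyond the scatter) was brought about by 4-fluorophenyl in place of 2-methylprop-1-en-1-yl on a saturated chain carbon bound to an aromatic nitrogen.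

The unmeasured compound 3, `O=C(C1CC1)N1CCN(Cc2nc3ccccc3n2Cc2ccccc2)CC1`, differs from compound 2 by hydrogen in place of fluoro on an aromatic carbon; cut one bond further out, this reads 4-fluorophenyl to phenyl, or 4-fluorobenzyl to benzyl.

Among the measured compounds shown here, no measured step bears directly on this change: the only step in hand, a number 41.6 percentage points lower from compound 1 to compound 2 (beyond the scatter), exchanges the whole group on the chain carbon rather than a single fluoro on an aromatic carbon, so it gives no guide to the size or direction of the loss of fluoro. With nothing to say that the fluoro matters, the expected step in this assay is a number 2.3 percentage points higher from compound 2 to compound 3 (within the scatter), which is no change beyond the scatter. Compound 3 is therefore estimated at 35% in this assay, within a range from 15% to 55%.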

Compound 3, a percentage reported as inhibition, at one concentration (the size of the read-out at that concentration, not a potency): 23.9%
Estimate against measurement, compound 3: 11.1 percentage points above, within the range that was stated.
By their numbers in this assay, from the lowest: compounds 3 and 2 (each within the scatter of the next); then compound 1.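

In this assay, hydrogen in place of fluoro on the aromatic carbon gives a number 8.8 percentage points lower from compound 2 to compound 3 (within the scatter), so at this place, para to a large group, the two compounds cannot be told apart and the fluoro shows no effect of its own on this read-out. The large gap seen earlier therefore does not depend on the fluoro: with the plain phenyl on the chain carbon it reappears as a number 50.4 percentage points lower from compound 1 to compound 3 (beyond the scatter), and both aromatic compounds stand well short of compound 1 in this pair of comparisons. The data offer no measured account of why the 2-methylprop-1-en-1-yl compound differs so much from the two aromatic ones.

From the compounds shown here alone, what stays open is which feature of the 2-methylprop-1-en-1-yl group goes with the higher number, a question that a fully saturated 3-methylbutyl chain or a cyclohexyl ring on the same chain carbon would address. The compounds shown also leave open whether a group larger than fluoro on the aromatic carbon para to the large group, such as a methoxy group or a carboxylic acid, would leave the number level or give a step beyond the scatter.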